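A methyl step from compound 3

A few compounds are considered here, and "the series" means these few. Any claim that something is new, unique, unknown or untested is made for them only; others in the source may bear on it.

Compounds measured so far in an ADME assay on microsomes from liver (Rattus norvegicus) for metabolic stability (on this read-out higher numbers stand for a longer-lived compound and lower numbers for a shorter-lived compound), are these
- Compound 1 `Cc1nc2cc(Nc3cc4c(cn3)ncn4CC3CC3)ccc2o1` gives 0.167 h as its half-life
- Compound 2 `Cc1nc(Nc2cnc3c(c2)OCC(=O)N3C)cc2c1ncn2CC1CC1` gives > 1.66 h which is a limit of the assay and not a number
- Compound 3 `CN1C(=O)COc2cc(Nc3ccc4ncn(CC5CC5)c4n3)cnc21` gives 0.117 h as its half-life

Among the compounds with values here, only two of these readings are numbers. Compound 3 gives 0.117 h and its nearest neighbour, compound 1, gives 0.167 h in this assay, so the two lie within the scatter of each other.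

Compound 4 `Cc1cc(Nc2cnc3c(c2)OCC(=O)N3C)nc2c1ncn2CC1CC1` has not yet been measured. It differs from compound 3 by methyl in place of hydrogen on an aromatic carbon, opposite the ring nitrogen methyl in place of hydrogen on an aromatic carbon in the shared core.

Within the data shown here, no measured pair of compounds differs in one place only, so the size of this change has no direct precedent here. In this assay a longer half-life is expected, by a step somewhat beyond the scatter. The expected change is a 3.0-fold higher number from compound 3 to compound 4 (0.48 log units; beyond the scatter) on this estimate. Compound 4 is estimated at 0.35 h with an expected range from 0.12 h to 1.2 h in this assay.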

Compound 4, half-life: 0.367 h
Beside the measured number, compound 4's estimate is 1.0-fold (0.02 log units) below it, within the range that was stated.
By their numbers in this assay, from the lowest: compounds 3 and 1 (each within the scatter of the next); then compound 4. At a limit, above all of these: compound 2.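

In this assay, within the data shown here, the change gives a 3.1-fold higher number from compound 3 to compound 4 (0.50 log units; beyond the scatter), the first step in this set between compounds that differ in one place. It shows that a single methyl in place of hydrogen on an aromatic carbon, opposite the ring nitrogen, is enough to carry the half-life beyond the scatter, though the step is only a modest one. One reading in the set remains a limit of the assay and not a number: the limit of > 1.66 h in this assay, at which 1 of the 4 values shown sits.

On these data alone, whether this position gives the same result with anything other than methyl stays open, as an ethyl group, a methoxy group or an amine there could lengthen the half-life further or shorten it. Among these compounds, with only this one step in hand, it also cannot be said whether methyl would do the same on another core.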